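Amide variation on the benzothiazolyl-aniline core

The source may hold more compounds than are shown below. What is called first, only, known or untested is meant among the compounds shown, and "the series" means these compounds.

Compound 1 `C=C(C)C(=O)Nc1cccc(-c2nc3ccccc3s2)c1`: > 25000 nM in an ADME assay on BJ cells (Homo sapiens) for inhibition, with a stated time of 72 h; a lower number here means that less compound is needed, a higher number that more compound is needed for the effect (a limit).
Compound 2 `CC(Cl)C(=O)Nc1cccc(-c2nc3ccccc3s2)c1`: > 25000 nM in this assay (a limit).
Compound 3 `CC(C)(CCl)C(=O)Nc1cccc(-c2nc3ccccc3s2)c1`: > 25000 nM in this assay (a limit).

Compound 2 gives in this assay only a limit, > 25000 nM, and no number. The other two values of the series are limits as well (the limit of > 25000 nM in this assay, at which 3 of the 3 values shown sit), so compound 2 cannot be placed against compound 1 or compound 3: the step that the two limits leave unreadable from compound 1 to compound 2 and the step that the two limits leave unreadable from compound 2 to compound 3 are both unreadable, as is the step that the two limits leave unreadable from compound 1 to compound 3.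

The next compound, compound 4 `O=C(Nc1cccc(-c2nc3ccccc3s2)c1)c1ccncc1Cl`, changes the amide substituent: 3-chloropyridin-4-yl in place of 1-chloroethyl on a carbonyl carbon. Going by the values given here, none of the measured steps can be read, so none gives a size to expect for the step into compound 4; what is known is only that every acyl group tried so far, including the 1-chloroethyl group of compound 2, sits at the limit.

Compound 4 is therefore expected to give in this assay a value of about 30000 nM, with a range from 5000 nM to 100000 nM, and the step that the limit leaves unreadable from compound 2 to compound 4 is estimated to be of no readable size; most likely compound 4 is also reported only as a limit.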

Compound 4, half-maximal effective concentration: > 25000 nM
Compound 4 was reported as a limit; the forecaster's own chance of this, stated with the estimate: 75%; the middle value lies beyond the limit too.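

Going by these compounds alone, compound 4 gives > 25000 nM in this assay, a limit, so no step to it from compound 1, compound 2 or compound 3 can be read. The series sits at a single limit: the limit of > 25000 nM in this assay, at which 4 of the 4 values shown sit.

The compounds shown leave open how these four amides rank against one another, and whether any acyl group on the shared core gives a measurable value in this assay.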